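Aryl amide series: anilide swap toward a nitrophenyl

A few compounds are considered here, and "the series" means these few. Any claim that something is new, unique, unknown or untested is made for them only; others in the source may bear on it.

Measured so far, read in a functional assay on HCT-116 cells (Homo sapiens) for inhibition, read by MTT assay, with a stated time of 72 h; on this read-out higher numbers stand for weaker inhibition and lower numbers for stronger inhibition:
- compound 1 `O=C(Nc1ccccc1[N+](=O)[O-])c1ccc(/N=N\c2c[nH]c3ccccc23)cc1` gives 208000 nM
- compound 2 `Cc1ccc(NC(=O)c2ccc(/N=N\c3c[nH]c4ccccc34)cc2)c(C)c1` gives 76100 nM
- compound 3 `COc1ccccc1NC(=O)c1ccc(/N=N\c2c[nH]c3ccccc23)cc1` gives 122000 nM

Compound 2 holds the lowest number of the three in this assay. Its nearest neighbour is compound 3, with a 1.6-fold higher number from compound 2 to compound 3 (0.20 log units; within the scatter), so the two are not separated. Compound 1 sits furthest away: a 2.7-fold lower number from compound 1 to compound 2 (0.44 log units; beyond the scatter), a separation that does hold. The step from compound 1 to compound 3, a 1.7-fold lower number from compound 1 to compound 3 (0.23 log units; within the scatter), is also unresolved.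

Compound 4 `O=C(Nc1ccc([N+](=O)[O-])cc1)c1ccc(/N=N\c2c[nH]c3ccccc23)cc1` is next. Relative to compound 2 the change is 4-nitrophenyl in place of 2,4-dimethylphenyl on an amide-type nitrogen.

Bearing on this is the step between the nitro-bearing anilide and the dimethyl anilide, a 2.7-fold lower number from compound 1 to compound 2 (0.44 log units; beyond the scatter): going from compound 2 back to a nitrophenyl amide would, read in reverse, be expected to raise the number by a modest margin. The nitro group now enters at a different place on the ring, so that step is only a guide, and compound 3 shows that the anilide choice can also leave the number within the scatter. Expected for compound 4 in this assay: a modest rise, a 2.1-fold higher number from compound 2 to compound 4 (0.32 log units; beyond the scatter). The estimate for compound 4 is 160000 nM, range 70000 nM to 360000 nM.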

Compound 4, half-maximal inhibitory concentration: 156000 nM
Beside the measured number, compound 4's estimate is 1.0-fold (0.01 log units) above it, and the stated range covers the measured number.
By their numbers in this assay, from the lowest: compounds 2, 3, 4 and 1 (each within the scatter of the next, the first and the last beyond it).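

On the amide-type nitrogen, 4-nitrophenyl in place of 2,4-dimethylphenyl gives a 2.0-fold higher number from compound 2 to compound 4 (0.31 log units; beyond the scatter) in this assay, so both nitrophenyl amides now stand apart from the dimethyl anilide, while the place of the nitro group on the ring is not resolved, with a 1.3-fold lower number from compound 1 to compound 4 (0.12 log units; within the scatter). The 2-methoxyphenyl amide is not separated from the 4-nitrophenyl amide either, with a 1.3-fold higher number from compound 3 to compound 4 (0.11 log units; within the scatter), and since it is also not separated from the 2,4-dimethylphenyl amide, the only resolved differences at this position are those between the dimethyl anilide and the two nitrophenyl amides. The data at hand offer no independent measurement that would explain this separation.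

As far as these compounds go, what remains open is whether the separation reflects the nitro group itself or the two methyl groups, which a plain phenyl amide or a 4-methylphenyl amide would help to tell apart. Also open, from the compounds shown here alone, is how this position responds to an aminophenyl or carboxyphenyl amide, or to a longer alkyl chain in place of the aryl ring on the amide-type nitrogen.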